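The source may hold more compounds than are shown below. What is called first, only, known or untested is meant among the compounds shown, and "the series" means these compounds.

Measured so far:
Compound 1, `NC1CCN(c2ccc3cc(NC(=O)CCc4ccc(C(F)(F)F)cc4)ccc3n2)C1`, gives 12 nM in an assay on isolated protein for displacement of a labelled ligand from melanin-concentrating hormone receptor 1 (Homo sapiens); a lower number here means a stronger inhibitor, a higher number a weaker inhibitor.
Compound 2, `O=C(CCc1ccc(C(F)(F)F)cc1)Nc1ccc2nc(N3CCC(c4ccccc4)C3)ccc2c1`, gives 25 nM in this assay.

Compound 2 holds the higher of the two numbers: the step of a 2.1-fold higher number from compound 1 to compound 2 (0.32 log units; beyond the scatter) separates it from compound 1, and that gap lies beyond the scatter, so compound 2 is the weaker binder of the pair.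

Compound 3, `Nc1ccc2cc(NC(=O)CCc3ccc(C(F)(F)F)cc3)ccc2n1`, has not yet been measured. It differs from compound 2 in a single place: amino in place of 3-phenylpyrrolidin-1-yl on an aromatic carbon. The one measured step, a 2.1-fold higher number from compound 1 to compound 2 (0.32 log units; beyond the scatter), concerns only the group on the saturated ring carbon inside the 3-phenylpyrrolidin-1-yl and was modest in size; no measured step takes that ring away altogether, so the change to compound 3 has no direct precedent among these numbers. What the data do show is that both measured compounds carry the ring and both bind strongly. The expectation for compound 3 is therefore a step to a higher number, beyond the scatter, a 4.8-fold higher number from compound 2 to compound 3 (0.68 log units; beyond the scatter), held with wide uncertainty. Compound 3 is estimated at 120 nM in this assay, within a range from 30 nM to 500 nM.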

Compound 3, half-maximal inhibitory concentration: 240 nM
Beside the measured number, compound 3's estimate is 2.0-fold (0.30 log units) below it, and the stated range covers the measured number.
By their numbers in this assay, from the lowest: compound 1; then compound 2; then compound 3.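

Among the compounds shown here, until this result, every compound carried a saturated five-membered ring on the aromatic carbon next to the ring nitrogen, so the numbers compared only the groups on that ring. Compound 3 removes the whole ring, and in this assay replacing 3-phenylpyrrolidin-1-yl with amino gives a 9.6-fold higher number from compound 2 to compound 3 (0.98 log units; beyond the scatter) and replacing 3-aminopyrrolidin-1-yl with amino gives a 20-fold higher number from compound 1 to compound 3 (1.30 log units; beyond the scatter) on the same aromatic carbon. Both steps are larger than a 2.1-fold higher number from compound 1 to compound 2 (0.32 log units; beyond the scatter) and so, across these three compounds, having a ring at this position counts for more than which of the two groups it carries, though no measurement given here explains why.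

Amino is the only small group shown at this position, so it remains open whether an open-chain group such as dimethylamino or diethylamino would stay close to the ring-bearing compounds or fall nearer to compound 3. As far as these compounds go, it is equally open how an unsubstituted pyrrolidin-1-yl, a piperidin-1-yl ring or a morpholine ring would compare here, and whether the group on the ring or the ring itself carries most of the difference.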